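Sulfur-bearing replacement on the ring nitrogen of compound 1

A few compounds are considered here, and "the series" means these few. Any claim that something is new, unique, unknown or untested is made for them only; others in the source may bear on it.

In a functional assay on RS4-11 cells (Homo sapiens) for inhibition, read by CCK-8 assay, with a stated time of 48 h (a higher number here means a weaker inhibitor, a lower number a stronger inhibitor), compound 1 `O=C(Nc1cccc([N+](=O)[O-])c1)N1CCN(S(=O)(=O)c2sccc2-c2ccccc2Oc2ccc(O)c(O)c2)CC1` gives 9800 nM, the higher of the two exact numbers in this small set. Compound 2 `COc1ccc(Oc2ccccc2-c2ccsc2S(=O)(=O)NCCNC(=S)Nc2cc(C(F)(F)F)cc(C(F)(F)F)c2)cc1OC` gives 3300 nM. Compound 3 `COc1ccc(Oc2ccccc2-c2ccsc2S(=O)(=O)N2CCN(C(=O)Nc3cccc([N+](=O)[O-])c3)CC2)cc1OC` is reported only as a limit, > 50000 nM.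

Compound 4 `O=[N+]([O-])c1ccc(NC(=S)N2CCN(S(=O)(=O)c3sccc3-c3ccccc3Oc3ccc(O)c(O)c3)CC2)cc1` departs from compound 1 at one place, on an amine nitrogen in a ring: a group of 12 heavy atoms (7 carbon, 2 nitrogen, 2 oxygen, 1 sulfur; one six-membered aromatic ring of carbon only) in place of a group of 12 heavy atoms (7 carbon, 2 nitrogen, 3 oxygen; one six-membered aromatic ring of carbon only), on an amine nitrogen in a ring. The (3-nitrophenyl)carbamoyl group leaves, and the group that enters has no common name.

Within the data shown here, the only measured step, an at least 5.1-fold higher number from compound 1 to compound 3 (0.70 log units; beyond the scatter), lies elsewhere in the molecule: 3,4-dimethoxyphenyl stands in place of 3,4-dihydroxyphenyl. Compound 4 keeps the 3,4-dihydroxyphenyl of compound 1, so that step bears on the choice of reference but does not size the present change. Among the measured compounds shown here, no measured step tests the change itself. For the measured compounds named here, compound 2, at 3300 nM, is the only measured compound with sulfur in its terminal group, but it differs from compound 1 in more than one place and offers only weak support for a lower number.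

The expected 1.8-fold lower number from compound 1 to compound 4 (0.25 log units; within the scatter) in this assay is small, leaning towards a lower number, and no step beyond the scatter is expected. For compound 4 the estimated value is 5500 nM, with an expected range from 1500 nM to 20000 nM.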

Compound 4, half-maximal inhibitory concentration: 9000 nM
Compound 4: middle estimate off by 1.6-fold (0.21 log units), on the low side; the range from low to high includes it.
By their numbers in this assay, from the lowest: compound 2; then compounds 4 and 1 (each within the scatter of the next). At a limit, above all of these: compound 3.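

In this assay the exchange on the amine nitrogen in a ring gives a 1.1-fold lower number from compound 1 to compound 4 (0.04 log units; within the scatter) so the sulfur-bearing group can stand in place of the (3-nitrophenyl)carbamoyl group with no readable change in the number. Among these compounds, this is the first direct reading at this position: the earlier step from the 3,4-dihydroxyphenyl to the 3,4-dimethoxyphenyl lies elsewhere in the molecule, and compound 2 differs from compound 1 in more than one place. No measurement shown gives a reason for the absence of a readable step at this position.

The step takes the entering group as a whole, so the contribution of the sulfur alone stays unresolved, as does the outcome of pairing this group with the 3,4-dimethoxyphenyl. Also open, going by these compounds, is whether a group on this nitrogen that lacks the aromatic ring, such as an acetyl group or a longer alkyl chain, would give a step beyond the scatter from compound 1.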